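The source may report more compounds than this note shows. Statements on the series, on what has been measured and on what is new or still open speak of the compounds shown alone.

In a functional assay for inhibition, with Rattus norvegicus as the target (a higher number here means a weaker inhibitor, a lower number a stronger inhibitor), compound 1 `CC(/N=c1\c(O)c(O)\c1=N/c1cccnc1)C(C)(C)C` gives 1950 nM. Compound 2 `C[C@@H](/N=c1\c(O)c(O)\c1=N/c1cccnc1)C(C)(C)C` gives 1900 nM, and compound 3 `CC(C)(C)/N=c1\c(O)c(O)\c1=N/c1cccnc1Cl` gives 1770 nM. All three values lie within the scatter of each other, so compound 1 sits in a flat group of numbers.

The next compound is compound 4 `CC(/N=c1\c(O)c(O)\c1=N/c1cncc(Br)c1)C(C)(C)C`, which is compound 1 with bromo in place of hydrogen on an aromatic carbon, turning pyridin-3-yl into 5-bromopyridin-3-yl: bromo in place of hydrogen on an aromatic carbon.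

For the measured compounds named here, the only measured step is a 1.0-fold lower number from compound 1 to compound 2 (0.01 log units; within the scatter), which stays within the scatter. What separates that pair is the fact that one of compounds 1 and 2 is drawn with a defined configuration and the other without, at the place where they differ, so it says nothing about a substituent on the aromatic ring. Going by the values given here, the series holds no measured step for bromo at this place, which leaves the direction open in this assay. The flat values, with compound 3 at 1770 nM, give no reason to expect a large shift, so no step beyond the scatter is expected, though with a wide margin.

The estimated step is a 1.3-fold lower number from compound 1 to compound 4 (0.11 log units; within the scatter). For compound 4 the expected value is 1500 nM, with an estimated range of 400 nM to 5000 nM.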

Compound 4, half-maximal inhibitory concentration: 11700 nM
Compound 4: middle estimate off by 7.8-fold (0.89 log units), on the low side; the whole stated range lies below it.
By their numbers in this assay, from the lowest: compounds 3, 2 and 1 (each within the scatter of the next); then compound 4.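

In this assay, for the compounds shown here, the change from pyridin-3-yl to 5-bromopyridin-3-yl gives a 6.0-fold higher number from compound 1 to compound 4 (0.78 log units; beyond the scatter), the first step beyond the scatter. Going by these compounds alone, this aromatic carbon, two atoms from the ring nitrogen, is therefore a place where the number responds to substitution, and bromo here gives a weaker inhibitor, whereas the only earlier step, a 1.0-fold lower number from compound 1 to compound 2 (0.01 log units; within the scatter), concerned the drawn configuration of a chain carbon and stayed within the scatter. Nothing at hand bears on why bromo has this effect.

From the compounds shown here alone, whether the loss belongs to bromo itself or to any group on this carbon stays open, and fluoro, methoxy or an amine at the same place would separate those readings. Also open, going by these compounds, is whether the step carries over to the defined configuration of compound 2.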